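The source may report more compounds than this note shows. Statements on the series, on what has been measured and on what is new or still open speak of the compounds shown alone.

Compound 1 `CCCC[C@]1(CC)CS(=O)(=O)c2ccc(OC)cc2[C@@H](c2ccccc2)[C@H]1O` gives 55 nM in an assay on cells for inhibition of ileal sodium/bile acid cotransporter (Homo sapiens); on this read-out higher numbers stand for weaker inhibition and lower numbers for stronger inhibition. Among the compounds with values here, compound 2 `CCCC[C@]1(CC)CS(=O)(=O)c2ccc(NS(C)(=O)=O)cc2[C@@H](c2ccccc2)[C@H]1O` gives 600 nM in this assay, the highest of the two numbers, and the only measured step, an 11-fold higher number from compound 1 to compound 2 (1.04 log units; beyond the scatter), shows how far it stands from compound 1. Compound 3 `CCCC[C@]1(CC)CS(=O)(=O)c2ccc([N+](C)(C)C)cc2[C@@H](c2ccccc2)[C@H]1O` differs from compound 2 by a group of 4 heavy atoms (3 carbon, 1 nitrogen; no ring) in place of a group of 5 heavy atoms (1 carbon, 1 nitrogen, 2 oxygen, 1 sulfur; no ring), on an aromatic carbon. Within the data shown here, no measured step tracks this exact exchange; the one step known shows that changing this group can move the number a great deal. Compound 3 is therefore expected to be about a 2.5-fold higher number from compound 2 to compound 3 (0.40 log units; beyond the scatter), with an estimated value of 1500 nM, within a range from 300 nM to 8000 nM.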

Compound 3, half-maximal inhibitory concentration: 83 nM
Compound 3: middle estimate off by 18-fold (1.26 log units), on the high side; measured number below the stated range.
By their numbers in this assay, from the lowest: compounds 1 and 3 (each within the scatter of the next); then compound 2.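

At this aromatic carbon, the group with net charge +1 and no hydrogen-bond donors or acceptors reverses most of the earlier loss: in this assay there is a 7.2-fold lower number from compound 2 to compound 3 (0.86 log units; beyond the scatter), while a 1.5-fold higher number from compound 1 to compound 3 (0.18 log units; within the scatter) shows no real difference from methoxy. Moving away from methoxy at this position therefore does not by itself weaken inhibition, as the methanesulfonamido group alone had suggested. No measurement here explains the difference between these groups. On these data alone, whether a dimethylamino group or a carboxylic acid at this carbon would match compound 3 or compound 2 remains open.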